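Swapping pyridin-2-yl for 4-ethylphenyl on a shared core

The source may report more compounds than this note shows. Statements on the series, on what has been measured and on what is new or still open speak of the compounds shown alone.

Compound 1 `CC(C)CN1C(=O)/C(=C/c2ccccc2O)S/C1=N\c1ccccc1` gives "not determined" (no result reported)
Compound 2 `CC(C)CN1C(=O)/C(=C/c2ccccn2)S/C1=N\c1ccccc1` gives > 100000 nM

In an ADME assay on HepG2 cells (Homo sapiens) for cytotoxicity, read by MTT assay, with a stated time of 48 h (a lower number here means a stronger inhibitor, a higher number a weaker inhibitor), compound 2 gives > 100000 nM as a limit of the assay and not a number. The only anchor is therefore the limit of > 100000 nM in this assay, at which 1 of the 2 values shown sits, and no exact number exists yet. Compound 3 `CCc1ccc(/C=C2\S/C(=N\c3ccccc3)N(CC(C)C)C2=O)cc1` carries 4-ethylphenyl in place of pyridin-2-yl on a double-bonded chain carbon bound to a double-bonded ring carbon, counted as 4-ethylphenyl in place of pyridin-2-yl on a double-bonded chain carbon bound to a double-bonded ring carbon and otherwise keeps the core of compound 2. Among the measured compounds shown here, no measured pair shows what such a swap does, so only a small move towards a stronger effect is expected, hardly beyond the scatter in this assay and perhaps none. The estimated change is an at least 1.1-fold lower number from compound 2 to compound 3 (0.04 log units; that floor lies within the scatter) on this view. For compound 3 the expected value is 90000 nM with an estimated range from 30000 nM to 200000 nM and a further limit would be no surprise.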

Compound 3, half-maximal inhibitory concentration: 84700 nM
Compound 3: middle estimate off by 1.1-fold (0.03 log units), on the high side; the measured number falls inside the stated range.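

In this assay, among the compounds shown here, compound 3 gives 84700 nM, the first exact number for a group on a double-bonded chain carbon bound to a double-bonded ring carbon in the shared core. Compound 2 gives > 100000 nM, which is a limit of the assay and not a number. Putting 4-ethylphenyl in place of pyridin-2-yl can therefore be read only as an at least 1.1-fold lower number from compound 2 to compound 3 (0.07 log units; that floor lies within the scatter), so the true size of the change remains unknown, and the comparison rests on a single anchor: the limit of > 100000 nM in this assay, at which 1 of the 3 values shown sits.

Compound 1 gives "not determined" (no result reported), so it offers no comparison with either of the other compounds. On these data alone, it remains open whether an amine or a carboxylic acid in place of the ethyl group, or a longer chain such as butyl, would move the number beyond the usual scatter.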